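A few compounds are considered here, and "the series" means these few. Any claim that something is new, unique, unknown or untested is made for them only; others in the source may bear on it.

Compound 1 `CC(=O)Nc1cccc(C2CCN(CCCn3c(-c4cccc(Cl)c4)nc4ccccc43)CC2)c1`: 5 nM in an assay for displacement of a labelled ligand from melanin-concentrating hormone receptor 1 (Homo sapiens), read by fluorescence; a higher number here means a weaker inhibitor, a lower number a stronger inhibitor
Compound 2 `CCc1ccc(-c2nc3ccccc3n2CCCN2CCC(c3cccc(NC(C)=O)c3)CC2)cc1`: 32 nM in this assay
Compound 3 `CC(=O)Nc1cccc(C2CCN(CCCn3c(-c4ccc(Cl)cc4Cl)nc4ccccc43)CC2)c1`: 3 nM in this assay

Of the three measured compounds, compound 3 gives the lowest number in this assay. Its nearest neighbour is compound 1, a step of a 1.7-fold lower number from compound 1 to compound 3 (0.22 log units; within the scatter) that lies within the scatter; its furthest is compound 2, a step of an 11-fold lower number from compound 2 to compound 3 (1.03 log units; beyond the scatter) that lies well beyond it. The third measured step, a 6.4-fold higher number from compound 1 to compound 2 (0.81 log units; beyond the scatter), is modest.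

Compound 4 `CC(=O)Nc1cccc(C2CCN(CCCn3c(-c4ccc(F)cc4Cl)nc4ccccc43)CC2)c1` differs from compound 3 by fluoro in place of chloro on an aromatic carbon. Within the data shown here, no measured step swaps a chloro for a fluoro; the steps at hand all change the substituent pattern on this ring more broadly. The step of a 1.7-fold lower number from compound 1 to compound 3 (0.22 log units; within the scatter) shows that adding a second chloro to that ring moved the number little, and the step of an 11-fold lower number from compound 2 to compound 3 (1.03 log units; beyond the scatter) shows that a sizeable change there can matter. For compound 4 the change is small in count and kept on the same ring, so only a small step is expected, if any beyond the scatter; a modest weakening is estimated, a 1.7-fold higher number from compound 3 to compound 4 (0.22 log units; within the scatter). Compound 4 is therefore expected to give about 5 nM, in the range 2 nM to 12 nM.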

Compound 4, half-maximal inhibitory concentration: 4 nM
Beside the measured number, compound 4's estimate is 1.3-fold (0.10 log units) above it, within the range that was stated.
By their numbers in this assay, from the lowest: compounds 3, 4 and 1 (each within the scatter of the next); then compound 2.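

In this assay, among these compounds, fluoro in place of chloro, para to a large group, is the first change of one halogen alone on this ring, and the step, a 1.3-fold higher number from compound 3 to compound 4 (0.12 log units; within the scatter), shows that the two cannot be told apart at this position. The 2-chloro-4-fluorophenyl ring also stays within the scatter of the 3-chlorophenyl ring, a 1.3-fold lower number from compound 1 to compound 4 (0.10 log units; within the scatter), while its gap to the 4-ethylphenyl ring lies beyond the scatter, an 8.0-fold lower number from compound 2 to compound 4 (0.90 log units; beyond the scatter). Among these four compounds, the three with halogens on this ring therefore sit together, and compound 2, the only one without a halogen there, stands apart.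

Nothing at hand gives a reason for any of these steps. From the compounds shown here alone, it remains open whether a methoxy group, a nitrile or a hydroxyl at this position would sit with the halogen compounds or with compound 2.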